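The compounds below may be only part of what the source reports. "The series", "measured", "known", "first", "only" and "open" are said of these compounds alone.

Working notes on the series.

Two compounds of the series have a number in a functional assay on cells for positive allosteric modulation of G-protein coupled receptor 68 (Homo sapiens), read by a luciferase reporter and cAMP accumulation, with a stated time of 30 min, at pH 6.8 and pH 8.3, in the presence of a further agent that is not named here; a lower number here means a less potent compound, a higher number a more potent compound, by a factor of ten per unit of this negative logarithm. Compound 1 `Nc1nc(NCc2ccccc2)nc(-c2cccc(F)c2CO)n1` gives 4.01 in this assay; compound 2 `Nc1nc(NCc2ccccc2)nc(-c2cc(F)ccc2CO)n1` gives 4.58 in the same assay. Compound 1 thus stands lowest of the two, and the gap to compound 2 lies beyond the scatter of the assay. Among the compounds with values here, the two differ in where the fluoro sits on the aromatic ring that bears the hydroxymethyl group; no other step among measured compounds is available, so there is nothing yet on how a change at the position used in compound 1 plays out.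

Compound 3 `COc1cccc(-c2nc(N)nc(NCc3ccccc3)n2)c1CO` is the next one to be measured. It differs from compound 1 as follows: methoxy in place of fluoro on an aromatic carbon. Both the group that leaves and the group that enters sit ortho to the hydroxymethyl group and meta to a large group, so the remainder of the molecule is unchanged.

Within the data shown here, with no comparable step measured, the expectation rests on compound 1 alone, at 4.01, and the step is expected to be small, a number 0.19 log units higher from compound 1 to compound 3 (within the scatter), not clearly beyond the scatter in either direction. Compound 3 is therefore expected to give about 4.2, with a range from 3.5 to 4.9.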

Compound 3, negative logarithm of the antagonist equilibrium constant: 4.16
For compound 3 the middle estimate is 0.04 log units above the measured one, and the stated range covers the measured number.
By their numbers in this assay, from the lowest: compounds 1 and 3 (each within the scatter of the next); then compound 2.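

In this assay, within the data shown here, methoxy in place of fluoro on the aromatic carbon ortho to a hydroxymethyl group gives a number 0.15 log units higher from compound 1 to compound 3 (within the scatter) and so provides the first measured step at this position. The exchange adds a heavy atom and a hydrogen-bond acceptor, yet the number does not move clear of the scatter, so at this position these two groups cannot be told apart in this assay. No measurement available here bears on the reason for this result.

This single pair does not show whether the position stays as undemanding with other groups: an amine, a carboxylic acid or a longer chain such as ethoxy could still move the number beyond the scatter. As far as these compounds go, it also remains open whether methoxy in place of fluoro would give a similarly small step at the position that carries the fluoro in compound 2, where the number is higher, or whether the result holds only for the position used in compound 1.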